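The compounds below may be only part of what the source reports. "The series", "measured", "known", "first", "only" and "open" are said of these compounds alone.

Measured so far in a functional assay on HT-29 cells (Homo sapiens) for inhibition, read by MTT assay, with a stated time of 48 h; a higher number here means a weaker inhibitor, a lower number a stronger inhibitor:
compound 1 `COc1cc(/C=C/c2ccc(NC(=O)/C=C/c3cccc(F)c3)cc2)cc(OC)c1` gives 16800 nM
compound 2 `COc1cc(/C=C/c2ccc(NC(=O)/C=C/c3ccccc3F)cc2)cc(OC)c1` gives 2820 nM
compound 3 `COc1cc(/C=C/c2ccc(NC(=O)/C=C/c3ccc(F)cc3F)cc2)cc(OC)c1` gives 18100 nM

Compound 3 stands at the highest number of the three, which in this assay means the weakest inhibitor. Its gap to compound 1 is small: a 1.1-fold higher number from compound 1 to compound 3 (0.03 log units; within the scatter). Its gap to compound 2 is clearer: a 6.4-fold higher number from compound 2 to compound 3 (0.81 log units; beyond the scatter).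

The step to compound 4 `COc1cc(/C=C/c2ccc(NC(=O)/C=C/c3ccc(Br)cc3)cc2)cc(OC)c1` changes only the ring at the far end of the chain: 4-bromophenyl in place of 2,4-difluorophenyl on a double-bonded chain carbon bound to a double-bonded chain carbon.

For the measured compounds named here, two measured steps touch the same ring. Moving a single fluorine from one spot to another gave a 6.0-fold lower number from compound 1 to compound 2 (0.78 log units; beyond the scatter), and adding a second fluorine gave a 6.4-fold higher number from compound 2 to compound 3 (0.81 log units; beyond the scatter). Both show that the pattern of substituents on this ring shifts the number by a modest amount, in either direction. Going by the values given here, no measured compound carries bromine, and none carries a single substituent in the 4-position, so the direction of this particular swap cannot be read from the data with confidence. A step of modest size, more likely downward than upward given that compound 3 sits at the top, is expected: a 1.6-fold lower number from compound 3 to compound 4 (0.22 log units; within the scatter).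

Compound 4 is therefore estimated at 11000 nM, within a range from 2500 nM to 40000 nM.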

Compound 4, half-maximal inhibitory concentration: 5260 nM
The estimate for compound 4 lay 2.1-fold (0.32 log units) above the measured number; the measured number falls inside the stated range.
By their numbers in this assay, from the lowest: compounds 2 and 4 (each within the scatter of the next); then compounds 1 and 3 (each within the scatter of the next).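

In this assay, 4-bromophenyl on this double-bonded chain carbon gives a 3.4-fold lower number from compound 3 to compound 4 (0.54 log units; beyond the scatter) and, in place of 3-fluorophenyl, gives a 3.2-fold lower number from compound 1 to compound 4 (0.50 log units; beyond the scatter) as well, which shows that this place accepts a halogen other than fluorine and that the low end of the series is not held by 2-fluorophenyl alone. The swap from 2-fluorophenyl gives a 1.9-fold higher number from compound 2 to compound 4 (0.27 log units; within the scatter) and so cannot separate these two rings, which differ in both the halogen and where it sits, while compound 1 shows that carrying just one halogen on the ring does not by itself bring the number down. Nothing available explains why these rings rank as they do in this cell assay.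

The compounds shown leave open whether the gain of compound 4 belongs to the bromine or to its place on the ring, a question that 4-fluorophenyl and 4-chlorophenyl rings would help to settle. As far as these compounds go, it also remains open how this place would respond to a group that is not a halogen, such as a methoxy group, an amine or a carboxylic acid on the same ring.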